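A few compounds are considered here, and "the series" means these few. Any claim that something is new, unique, unknown or untested is made for them only; others in the source may bear on it.

Series notes. Compound 1 `O=S(=O)(Nc1nnc(SCc2ccccc2)s1)c1ccccc1` and compound 2 `O=S(=O)(Nc1nnc(SCc2ccc(Cl)cc2)s1)c1ccccc1` share one core; compound 3 `COc1ccc(S(=O)(=O)Nc2nnc(SCc3ccccc3)s2)cc1` and compound 4 `COc1ccc(S(=O)(=O)Nc2nnc(SCc3ccc(Cl)cc3)s2)cc1` share another. In a functional assay on MCF7 cells (Homo sapiens) for cytotoxicity, tested at 250 uM (a lower number here means a stronger effect, a higher number a weaker effect of the compound at the concentration tested), compound 1 gives 65%, compound 2 gives 68% and compound 3 gives 53%. The change chloro in place of hydrogen on an aromatic carbon gives a number 3 percentage points higher from compound 1 to compound 2 (within the scatter). The two cores differ by methoxy in place of hydrogen on an aromatic carbon, which gives a number 12 percentage points lower from compound 1 to compound 3 (beyond the scatter), leaving compound 3 with the lowest number of the three measured. Compound 4 differs from compound 3 by chloro in place of hydrogen on an aromatic carbon, the same change that separates compound 2 from compound 1, at a place described in the same words. Because compound 1 to compound 2 gave a number 3 percentage points higher from compound 1 to compound 2 (within the scatter), the step from compound 3 to compound 4 is expected to be a number 3 percentage points higher from compound 3 to compound 4 (within the scatter). Compound 4 is therefore estimated at 56% in this assay, within 45% to 67%.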

Compound 4, a percentage reported as activity, at one concentration (the size of the read-out at that concentration, not a potency): 37%
For compound 4 the middle estimate is 19 percentage points above the measured one; the measured number lies below the stated range.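

On the core of compound 3, chloro in place of hydrogen gives a number 16 percentage points lower from compound 3 to compound 4 (beyond the scatter), so in this assay this change does not carry over unchanged from the core of compound 1: the same change on two cores in this assay, a number 3 percentage points higher (within the scatter) from compound 1 to compound 2 and a number 16 percentage points lower (beyond the scatter) from compound 3 to compound 4, 19 percentage points apart, beyond the scatter of two such steps. Methoxy in place of hydrogen, read with chloro already present, gives a number 31 percentage points lower from compound 2 to compound 4 (beyond the scatter), and this too departs from the earlier step: the same change on two cores in this assay, a number 12 percentage points lower (beyond the scatter) from compound 1 to compound 3 and a number 31 percentage points lower (beyond the scatter) from compound 2 to compound 4, 19 percentage points apart, beyond the scatter of two such steps. Both readings rest on the same four compounds and form one finding on one pair of cores, which shows that the two changes are not additive here but not why, nor how chloro would behave on any other core.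

Open, from the compounds shown here alone, is whether bromo or methyl at the place of chloro would follow compound 4 or compound 2. Also open, going by these compounds, is whether an amine in place of methoxy would shift the chloro step in the same way.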